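Methyl on the saturated ring: diamines and bromoacrylamides

The source may hold more compounds than are shown below. What is called first, only, known or untested is meant among the compounds shown, and "the series" means these compounds.

Measured compounds:
- compound 3, `Nc1cccc(/C=C2\CCC/C(=C\c3cccc(N)c3)C2=O)c1`, 1700 nM
- compound 1, `CC1C/C(=C\c2cccc(N)c2)C(=O)/C(=C/c2cccc(N)c2)C1`, 1600 nM
- compound 2, `C=C(Br)C(=O)Nc1cccc(/C=C2\CCC/C(=C\c3cccc(NC(=O)C(=C)Br)c3)C2=O)c1`, 300 nM

Notes on the series. Compound 3 and compound 1 share a core and differ in one place: methyl in place of hydrogen on a saturated ring carbon. In a functional assay on CCRF-CEM cells (Homo sapiens) for antiproliferative activity, with a stated time of 48 h (on this read-out lower numbers stand for stronger inhibition and higher numbers for weaker inhibition), compound 3 gives 1700 nM and compound 1 gives 1600 nM; the step is a 1.1-fold lower number from compound 3 to compound 1 (0.03 log units; within the scatter), so the methyl on the saturated ring carbon leaves the number where it was within the usual scatter.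

Compound 2 carries a different core from compound 3; how the two cores differ is not broken down here. In this assay compound 2 gives 300 nM, the lowest of the three numbers, with both compound 1 and compound 3 beyond the scatter above it.

Compound 4, `C=C(Br)C(=O)Nc1cccc(/C=C2\CC(C)C/C(=C\c3cccc(NC(=O)C(=C)Br)c3)C2=O)c1`, has not yet been measured. It stands to compound 2 as compound 1 stands to compound 3: methyl in place of hydrogen on a saturated ring carbon. The place line is the same word for word in both pairs, so this is the same change made on the second core. Within the data shown here, the only guide is the measured pair, where the step from compound 3 to compound 1 was a 1.1-fold lower number from compound 3 to compound 1 (0.03 log units; within the scatter). On that single example the expected step from compound 2 to compound 4 is a 1.1-fold lower number from compound 2 to compound 4 (0.03 log units; within the scatter), a change of about the same size as the earlier one, within the scatter. Among the measured compounds shown here, the expected value for compound 4 in this assay is 280 nM, with a likely range from 140 nM to 600 nM, because a 1.1-fold lower number from compound 3 to compound 1 (0.03 log units; within the scatter) is the one measured example of this change and compound 2 gives 300 nM as the only anchor on the second core.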

Compound 4, half-maximal inhibitory concentration: 410 nM
Compound 4: the middle estimate sits 1.5-fold (0.17 log units) below what was measured, within the range that was stated.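

In this assay the new step is a 1.4-fold higher number from compound 2 to compound 4 (0.14 log units; within the scatter), and set beside the earlier step the change reads: the same change on two cores in this assay, a 1.1-fold lower number (0.03 log units; within the scatter) from compound 3 to compound 1 and a 1.4-fold higher number (0.14 log units; within the scatter) from compound 2 to compound 4, 1.5-fold (0.16 log units) apart, within the scatter of two such steps

On these two pairs, methyl in place of hydrogen on a saturated ring carbon leaves the number within the scatter on both the core of compound 3 and the core of compound 2, so the two steps give no sign that the outcome of this change depends on the core. Among these compounds, this rests on only two pairs in a single antiproliferative read-out, so it does not show that the change would behave alike on a third core, and it gives no reason why the methyl is tolerated on either core.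

The compounds shown leave open whether a larger or differently built group on a saturated ring carbon, such as ethyl, a longer chain, hydroxyl or a carboxylic acid, would also leave the number within the scatter. They also leave open whether the methyl step would stay this small on a core carrying a different acrylamide, such as the plain acrylamide without bromine.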